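Phenyl Carbamate Selenocyanates: Removing a Methyl Group

This account rests on a few compounds, and the source may have more. Where it says the series, first, only, none or still open, it means among the compounds named here.

Measured so far:
- compound 1, `CCCCCCOC(=O)Nc1ccc([Se]C#N)cc1`: 46200 nM
- compound 2, `Cc1ccc(OC(=O)Nc2ccc([Se]C#N)cc2)cc1`: 44700 nM

Of the compounds shown here, two sharing the same selenocyanate-bearing core have been tested in a functional assay on CCRF-CEM cells (Homo sapiens) for cytotoxicity, read by MTT assay, with a stated time of 72 h; on this read-out higher numbers stand for weaker inhibition of growth and lower numbers for stronger inhibition of growth. Compound 1, which carries a hexyl chain on the carbamate oxygen, gives 46200 nM. Compound 2, which carries a methyl-substituted aromatic ring in that position, gives 44700 nM. The two numbers sit within the usual scatter of each other, so on the present evidence compound 2 cannot be told apart from compound 1; a very different group on the carbamate oxygen has left the read-out essentially unchanged.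

Compound 3, `N#C[Se]c1ccc(NC(=O)Oc2ccccc2)cc1`, is the next compound to be measured. It differs from compound 2 in one place: hydrogen in place of methyl on an aromatic carbon. For the measured compounds named here, no measured pair shows this exact change, so the size of its effect has to be judged from what is at hand. Since a much larger change between compound 1 and compound 2 produced nothing beyond the scatter, a small change of this kind is expected to produce no step beyond the scatter either, in either direction. Compound 3 is therefore estimated at 45000 nM, with a likely range from 25000 nM to 80000 nM, which corresponds to an expected step of a 1.0-fold higher number from compound 2 to compound 3 (0.00 log units; within the scatter).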

Compound 3, concentration for total growth inhibition: 48000 nM
Estimate against measurement, compound 3: 1.1-fold (0.03 log units) below, and the stated range covers the measured number.
By their numbers in this assay, from the lowest: compounds 2, 1 and 3 (each within the scatter of the next).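

For the compounds shown here, this is the first direct look at the ring carbon para to a large group: in this assay, hydrogen in place of methyl there gives a 1.1-fold higher number from compound 2 to compound 3 (0.03 log units; within the scatter), so compound 2 and compound 3 cannot be told apart and the methyl group shows no measurable contribution to this read-out. The carbamate oxygen can now be compared with an unsubstituted phenyl group as well, and phenyl in place of hexyl gives a 1.0-fold higher number from compound 1 to compound 3 (0.02 log units; within the scatter), so this pair also cannot be told apart. Nothing available explains why neither exchange separates the compounds in this assay.

From the compounds shown here alone, at the ring carbon, only methyl and hydrogen are covered, so it remains open whether a chlorine atom, a methoxy group, an amine or a carboxylic acid there would give a number beyond the scatter. On the carbamate oxygen, only hexyl and the two aromatic rings are covered, which leaves open what a longer chain or a ring bearing its methyl group at another carbon would do.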